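Swapping Oxolan-2-yl for (Oxan-4-yl)methyl on the Amide

The source may report more compounds than this note shows. Statements on the series, on what has been measured and on what is new or still open speak of the compounds shown alone.

Compound 1 `O=C(C1CC1)N1CCc2nc(C#Cc3ccccc3)sc2C1` carries a cyclopropyl on the carbonyl carbon, and in an assay on HEK293 cells for negative allosteric modulation of metabotropic glutamate receptor 5 (Homo sapiens), read by FLIPR, with a stated time of 1 h (a lower number here means a stronger inhibitor, a higher number a weaker inhibitor), compound 1 gives 290 nM. Compound 2 `CC1CC1C(=O)N1CCc2nc(C#Cc3ccccc3)sc2C1` adds a methyl on a saturated ring carbon, and in this assay compound 2 reaches only the limit > 10000 nM. Compound 3 `O=C(C1CCCO1)N1CCc2nc(C#Cc3ccccc3)sc2C1` puts an oxolan-2-yl in place of the cyclopropyl, and compound 3 likewise sits at the limit > 10000 nM, so its standing is known only as a limit (the limit of > 10000 nM in this assay, at which 2 of the 3 values shown sit). The step of an at least 34-fold higher number from compound 1 to compound 3 (1.53 log units; beyond the scatter) is large, as is an at least 34-fold higher number from compound 1 to compound 2 (1.53 log units; beyond the scatter), while a step that the two limits leave unreadable from compound 2 to compound 3 cannot be read. Compound 4 `O=C(CC1CCOCC1)N1CCc2nc(C#Cc3ccccc3)sc2C1` differs from compound 3 by (oxan-4-yl)methyl in place of oxolan-2-yl on a carbonyl carbon. Since the move away from cyclopropyl in compound 3 already cost everything measurable, compound 4 is expected to stay weak. The step of a number no higher from compound 3 to compound 4 (the limit leaves the size open) is estimated to be none beyond the scatter. Compound 4 is therefore estimated at 10000 nM, within 2500 nM to 30000 nM.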

Compound 4, half-maximal inhibitory concentration: > 10000 nM
Compound 4: a limit, no number; the forecaster's own chance of this, stated with the estimate: 65%; the middle value lies on the limit itself.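

Putting (oxan-4-yl)methyl in place of cyclopropyl on the carbonyl carbon gives an at least 34-fold higher number from compound 1 to compound 4 (1.53 log units; beyond the scatter), so in this assay a six-membered ring with one oxygen, like the five-membered oxolan-2-yl, gives no measured number. The steps among compound 2, compound 3 and compound 4 cannot be read, with limits at both ends. Of the groups shown on this carbonyl carbon, only cyclopropyl gives a number, and the others all stand at one limit: the limit of > 10000 nM in this assay, at which 3 of the 4 values shown sit.

Still open, going by these compounds, is whether cyclobutyl or cyclopentyl, rings without the oxygen, would give a measured number here.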